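The source may report more compounds than this note shows. Statements on the series, on what has been measured and on what is new or still open speak of the compounds shown alone.

Of the compounds shown here, two have been measured so far in an ADME assay on microsomes from liver (Mus musculus, strain NMRI) for metabolic stability, tested at 2.5 uM; on this read-out higher numbers stand for fast clearance and lower numbers for slow clearance. Compound 1, `Fc1cc(Cl)ccc1-c1ccc(Cn2nnc3c(C(F)(F)F)cccc32)cn1`, gives 0.1 mL/min/g in this assay. Compound 2, `Brc1cccc2c1nnn2CC1CCCC1`, gives 11.4 mL/min/g in this assay; of the two numbers this is the higher. The gap between compound 2 and compound 1 lies far beyond the scatter of repeated measurements. Compound 3, `Brc1cccc2c1nnn2CC1CC1`, has not been measured yet. It differs from compound 2 in one place: cyclopropyl in place of cyclopentyl on a saturated chain carbon bound to an aromatic nitrogen. Among the compounds with values here, no measured pair shows this exact change, so there is no step from the data to lean on. Putting cyclopropyl in place of cyclopentyl is expected to move the number down by a moderate amount, in the step of a 2.3-fold lower number from compound 2 to compound 3 (0.36 log units; beyond the scatter), probably just beyond the scatter, while leaving compound 3 well above compound 1. The estimate for compound 3 in this assay is 5 mL/min/g, with a range from 2 mL/min/g to 12 mL/min/g.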

Compound 3, intrinsic clearance in a liver preparation (reported as CLH), per the amount of preparation that the assay uses: 7.7 mL/min/g
Compound 3: the middle estimate sits 1.5-fold (0.19 log units) below what was measured; measured number inside the range.
By their numbers in this assay, from the lowest: compound 1; then compounds 3 and 2 (each within the scatter of the next).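

Cyclopropyl in place of cyclopentyl, on a saturated chain carbon bound to an aromatic nitrogen, is the first single change that can be read in this assay, and it gives a 1.5-fold lower number from compound 2 to compound 3 (0.17 log units; within the scatter). On this read-out compound 2 and compound 3 cannot be told apart, so for these two rings the size of the ring at this place makes no visible difference to clearance. Nothing measured here offers an explanation for this result.

From the compounds shown here alone, whether a longer chain, a cyclohexyl ring or an amine at this place would also leave the number where it is remains open. Compound 1 differs from compound 3 in more than one place, so the compounds shown do not tell which of its parts goes with its number.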